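Removing the Remaining Acetyl from Compound 2

The compounds below may be only part of what the source reports. "The series", "measured", "known", "first", "only" and "open" are said of these compounds alone.

Of the compounds shown here, three sharing one core have been measured in a functional assay on PC-3 cells (Homo sapiens) for cytotoxicity; a higher number here means a weaker inhibitor, a lower number a stronger inhibitor. Compound 1 `COC(=O)/C=C/c1oc(=O)c(COC(C)=O)c(OC)c1CO` gives 1090 nM, compound 3 `COC(=O)/C=C/c1oc(=O)c(COC(C)=O)c(OC)c1COC(C)=O` gives 980 nM, and compound 2 `COC(=O)/C=C/c1oc(=O)c(CO)c(OC)c1COC(C)=O` gives 5900 nM. Compound 2 thus has the highest number of the three, and its gaps to both others lie beyond the scatter.

Compound 4 `COC(=O)/C=C/c1oc(=O)c(CO)c(OC)c1CO` follows from compound 2 by one change: hydrogen in place of acetyl on an oxygen on a saturated carbon. This is hydrogen in place of acetyl on an oxygen on a saturated carbon, or acetoxymethyl to hydroxymethyl, and it leaves compound 4 with no acetyl.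

Among the measured compounds shown here, the acetyl lost here is the one gained in the step showing a 1.1-fold lower number from compound 1 to compound 3 (0.05 log units; within the scatter). That is the closest evidence, and it suggests little change, although both of those compounds carry the other acetyl, which compound 2 and compound 4 lack. That other acetyl accounts for a 6.0-fold lower number from compound 2 to compound 3 (0.78 log units; beyond the scatter), so a second acetyl can matter in this series, and the caution points toward a slightly higher number.

In this assay, the expected outcome is therefore no step beyond the scatter, estimated as a 1.2-fold higher number from compound 2 to compound 4 (0.07 log units; within the scatter). For compound 4 the estimate is 7000 nM, with an expected range from 3000 nM to 20000 nM.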

Compound 4, half-maximal inhibitory concentration: > 50000 nM
Compound 4: no number, only a limit; the forecaster's own chance of this, stated with the estimate: 10%; middle value at least 7.1-fold (0.85 log units) away from the limit.
By their numbers in this assay, from the lowest: compounds 3 and 1 (each within the scatter of the next); then compound 2. At a limit, above all of these: compound 4.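

In this assay compound 4 gives > 50000 nM, which is a limit of the assay and not a number. Removing the acetyl from this oxygen on a saturated carbon gives a step within the scatter when the other acetyl is present, but an at least 8.4-fold higher number from compound 2 to compound 4 (0.92 log units; beyond the scatter) when it is absent, so the size of the same change depends on the core that carries it: the same change on two cores in this assay, a 1.1-fold lower number (0.05 log units; within the scatter) from compound 1 to compound 3 and an at least 8.4-fold lower number (0.92 log units; beyond the scatter) from compound 4 to compound 2, at least 7.6-fold (0.88 log units) apart, beyond the scatter of two such steps The other acetyl shows the same dependence, with an at least 45-fold higher number from compound 1 to compound 4 (1.66 log units; beyond the scatter), so the two acetyl positions do not act independently in these four compounds: the same change on two cores in this assay, a 6.0-fold lower number (0.78 log units; beyond the scatter) from compound 2 to compound 3 and an at least 45-fold lower number (1.66 log units; beyond the scatter) from compound 4 to compound 1, at least 7.6-fold (0.88 log units) apart, beyond the scatter of two such steps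

Acetyl is the only group shown on these oxygens apart from hydrogen, which leaves open whether the lower numbers need an ester at all or only need the hydroxy to be capped. A methyl ether or a longer acyl chain such as butyryl in place of acetyl would address that question, as would an amine in place of the hydroxy.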